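Cytotoxicity in Liver Cells Across a Shared Core

A few compounds are considered here, and "the series" means these few. Any claim that something is new, unique, unknown or untested is made for them only; others in the source may bear on it.

Compound 1, `CN(c1cc2ncc(=O)[nH]c2cc1NC(=S)NC(=O)c1ccc(F)cc1)C1CCCCC1`, in an ADME assay on Huh-7 cells (Homo sapiens) for cytotoxicity (on this read-out lower numbers stand for stronger inhibition and higher numbers for weaker inhibition), gives 11400 nM.
Compound 2, `CN(c1cc2ncc(=O)[nH]c2cc1NC(=S)NC(=O)/C=C/c1ccccc1)C1CCCCC1`, in this assay gives 11000 nM.
Compound 3, `CN(c1cc2ncc(=O)[nH]c2cc1NC(=S)Nc1ccccc1)C1CCCCC1`, in this assay gives 49600 nM.

Among the three, compound 3 stands highest in this assay. The two steps that reach it, a 4.4-fold higher number from compound 1 to compound 3 (0.64 log units; beyond the scatter) and a 4.5-fold higher number from compound 2 to compound 3 (0.65 log units; beyond the scatter), are both modest and beyond the scatter, whereas a 1.0-fold lower number from compound 1 to compound 2 (0.02 log units; within the scatter) lies within it.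

Compound 4, `CN(c1cc2ncc(=O)[nH]c2cc1Nc1nc(-c2cccs2)cs1)C1CCCCC1`, has not been measured in this assay. It differs from compound 3 as follows: a group of 10 heavy atoms (7 carbon, 1 nitrogen, 2 sulfur; one five-membered aromatic ring with 1 hetero atom, one five-membered aromatic ring with 2 hetero atoms) in place of a group of 9 heavy atoms (7 carbon, 1 nitrogen, 1 sulfur; one six-membered aromatic ring of carbon only), on a nitrogen on an aromatic ring. For the measured compounds named here, none of the measured steps touches this group, so no direct precedent exists. Going by the values given here, the steps into compound 3 show only that the number on this core can move by a modest amount when the group on the nitrogen changes, and the shift from compound 3 to compound 4 is of a different kind from those. The expected step is therefore a 1.7-fold lower number from compound 3 to compound 4 (0.22 log units; within the scatter), with a wide margin in either direction. Compound 4 is estimated at 30000 nM, within a range from 8000 nM to 100000 nM.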

Compound 4, half-maximal inhibitory concentration: 71300 nM
The estimate for compound 4 lay 2.4-fold (0.38 log units) below the measured number; the measured number falls inside the stated range.
By their numbers in this assay, from the lowest: compounds 2 and 1 (each within the scatter of the next); then compounds 3 and 4 (each within the scatter of the next).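

In this assay, for the compounds shown here, the step to the 4-(thiophen-2-yl)-1,3-thiazol-2-yl group, a 1.4-fold higher number from compound 3 to compound 4 (0.16 log units; within the scatter), lies within the scatter, although the entire group on the nitrogen on an aromatic ring is replaced and the hydrogen-bond donor of the leaving group has no counterpart in the entering one. The earlier steps shown here changed only what sits on an amide-type nitrogen of the same thiocarbonyl-bearing unit, so they could not show that the read-out on this core stays at the level of compound 3 when that unit gives way to two linked five-membered aromatic rings. No supporting measurement bears on this result, so the data offer no explanation of it.

The compounds shown do not separate the thiazole from the thiophene, so it remains open whether a plain 1,3-thiazol-2-yl group without the thiophene would stay at this level. Going by these compounds, it is also open whether a carboxylic acid or an amine carried on the thiophene would move the number towards the lower values of compound 1 and compound 2, or leave it where it stands.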